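This account rests on a few compounds, and the source may have more. Where it says the series, first, only, none or still open, it means among the compounds named here.

Compound 1, `O=C1c2c[n+]([O-])c3ccccc3c2C(=O)c2c1c1ccccc1n2Cc1cn(C[C@@H](O)CO)nn1`: in a functional assay on MDA-MB-231 cells (Homo sapiens) for cytotoxicity, read by MTT assay, with a stated time of 72 h (on this read-out higher numbers stand for weaker inhibition and lower numbers for stronger inhibition), compound 1 gives 670 nM.
Compound 2, `O=C1c2c[n+]([O-])c3ccccc3c2C(=O)c2c1c1ccccc1n2Cc1cn(CC(O)CO)nn1`: in this assay compound 2 gives 1290 nM.
Compound 3, `CCCCN1CCN(CCCCn2c3c(c4ccccc42)C(=O)c2c[n+]([O-])c4ccccc4c2C3=O)CC1`: in this assay compound 3 gives 900 nM.

Among these three numbers compound 3 stands second highest; its nearest neighbour is compound 1 and its furthest compound 2, and both gaps lie within the scatter. For the measured compounds named here, the only measured step, a 1.9-fold higher number from compound 1 to compound 2 (0.28 log units; within the scatter), also stays within the scatter, and it rests on the fact that one of compounds 1 and 2 is drawn with a defined configuration and the other without, at the place where they differ rather than on any change of atoms. Compound 4, `CN1CCN(CCCCn2c3c(c4ccccc42)C(=O)c2c[n+]([O-])c4ccccc4c2C3=O)CC1`, differs from compound 3 by hydrogen in place of propyl on a saturated chain carbon bound to an amine nitrogen in a ring. Going by the values given here, no measured step touches a change of this kind, so nothing points to a step beyond the scatter in either direction. Compound 4 is therefore expected to give about 1000 nM, within 400 nM to 2500 nM. This estimate means a step of a 1.1-fold higher number from compound 3 to compound 4 (0.05 log units; within the scatter), expected to fall within the scatter.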

Compound 4, half-maximal inhibitory concentration: 110 nM
Compound 4: middle estimate off by 9.1-fold (0.96 log units), on the high side, outside the stated range (below it).
By their numbers in this assay, from the lowest: compound 4; then compounds 1, 3 and 2 (each within the scatter of the next).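

Going from 4-butylpiperazin-1-yl to 4-methylpiperazin-1-yl gives the first single change among these compounds that lies beyond the scatter, an 8.2-fold lower number from compound 3 to compound 4 (0.91 log units; beyond the scatter), so the end of this side chain matters in this assay. The change of 1-(2,3-dihydroxypropyl)-1H-1,2,3-triazol-4-yl to 3-(4-methylpiperazin-1-yl)propyl also goes beyond the scatter, with a 12-fold lower number from compound 2 to compound 4 (1.07 log units; beyond the scatter) and a 6.1-fold lower number from compound 1 to compound 4 (0.78 log units; beyond the scatter). Nothing available explains why these numbers fall.

The compounds shown leave open how an ethyl or propyl group would read on the piperazine, and whether a morpholine would keep the lower number of compound 4.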